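Working notes: expecting compound 4 from compound 1

The source may hold more compounds than are shown below. What is called first, only, known or untested is meant among the compounds shown, and "the series" means these compounds.

Measured so far:
compound 1 `CC(C)(C)c1ccc(C(=O)N2CCC3(CC2)C(=O)N(CC(=O)N2CCC(CCO)CC2)CN3c2ccccc2)cc1` gives 2600 nM
compound 2 `CC(C)(C)OC(=O)NC1CCN(C(=O)CN2CN(c3ccccc3)C3(CCN(C(=O)c4ccc(C(C)(C)C)cc4)CC3)C2=O)CC1` gives 8300 nM
compound 3 `COC(=O)CCCNC(=O)CN1CN(c2ccccc2)C2(CCN(C(=O)c3ccc(C4CCCCC4)cc3)CC2)C1=O` gives 2500 nM

In an assay on HEK293 cells for displacement of a labelled ligand from NPC1-like intracellular cholesterol transporter 1 (Homo sapiens) (a lower number here means a stronger inhibitor, a higher number a weaker inhibitor), compound 1 stands second highest of the three numbers; compound 3 sits within the scatter of it, while compound 2 lies apart, with a 3.2-fold higher number from compound 1 to compound 2 (0.50 log units; beyond the scatter). Compound 4 `CC1CCCN(C(=O)CN2CN(c3ccccc3)C3(CCN(C(=O)c4ccc(C(C)(C)C)cc4)CC3)C2=O)C1` differs from compound 1 by 3-methylpiperidin-1-yl in place of 4-(2-hydroxyethyl)piperidin-1-yl on a carbonyl carbon. Going by the values given here, the only measured step touching the same region is the one from compound 1 to compound 2, where a different group replaced 2-hydroxyethyl on the saturated ring carbon and the number went up modestly; no measured pair separates the 2-hydroxyethyl alone from that ring. A small weakening, near the edge of the scatter, is therefore expected, a 1.5-fold higher number from compound 1 to compound 4 (0.19 log units; within the scatter). Compound 4 is estimated at 4000 nM, with a range from 1500 nM to 12000 nM.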

Compound 4, half-maximal inhibitory concentration: 12000 nM
For compound 4 the middle estimate is 3.0-fold (0.48 log units) below the measured one; low and high end bracket the measured number.
By their numbers in this assay, from the lowest: compounds 3 and 1 (each within the scatter of the next); then compounds 2 and 4 (each within the scatter of the next).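

In this assay, replacing the whole substituent on this carbonyl carbon, 3-methylpiperidin-1-yl in place of 4-(2-hydroxyethyl)piperidin-1-yl, gives a 4.6-fold higher number from compound 1 to compound 4 (0.66 log units; beyond the scatter) and takes out the hydrogen-bond donor and acceptor counted in the leaving group. Together with a 3.2-fold higher number from compound 1 to compound 2 (0.50 log units; beyond the scatter), this makes two changes at this end of the molecule that raise the number, and neither replacement improves on compound 1. No measurement here accounts for the step.

The compounds shown do not separate the loss of the 2-hydroxyethyl chain from the appearance of the 3-methyl group. Going by these compounds, whether a 4-(2-aminoethyl)piperidin-1-yl group or a carboxylic acid on that chain would hold or lower the number also stays open.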